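Ether substituent swap: cyclopentyl to butyl

A few compounds are considered here, and "the series" means these few. Any claim that something is new, unique, unknown or untested is made for them only; others in the source may bear on it.

The series shares one core; compound 1 `Cc1ccc(Oc2ccc(C(=O)N3CCOC3=O)cc2)cc1` carries a 4-methylphenyl on the ether oxygen, compound 2 `O=C1OCCN1C(=O)c1ccc(OC2CCCCC2)cc1` a cyclohexyl and compound 3 `O=C1OCCN1C(=O)c1ccc(OC2CCCC2)cc1` a cyclopentyl. In an assay on HEK293 cells for inhibition of N-acylethanolamine-hydrolyzing acid amidase (Rattus norvegicus), read by LC-MS, with a stated time of 30 min (a higher number here means a weaker inhibitor, a lower number a stronger inhibitor), compound 1 gives 6400 nM, compound 2 gives 92 nM and compound 3 gives 120 nM. Compound 3 thus sits close to compound 2 and far from compound 1. Compound 4 `CCCCOc1ccc(C(=O)N2CCOC2=O)cc1` differs from compound 3 by butyl in place of cyclopentyl on an oxygen on an aromatic ring. The steps seen so far, a 70-fold lower number from compound 1 to compound 2 (1.84 log units; beyond the scatter) and a 53-fold lower number from compound 1 to compound 3 (1.73 log units; beyond the scatter), set aryl against cycloalkyl, while a 1.3-fold higher number from compound 2 to compound 3 (0.12 log units; within the scatter) concerns ring size only. None tests ring against chain, so only a small step in this assay is expected, if anything toward a higher number. Compound 4 is estimated at 200 nM, range 60 nM to 700 nM, meaning an expected 1.7-fold higher number from compound 3 to compound 4 (0.22 log units; within the scatter).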

Compound 4, half-maximal inhibitory concentration: 1340 nM
Estimate against measurement, compound 4: 6.7-fold (0.83 log units) below, outside the stated range (above it).
By their numbers in this assay, from the lowest: compounds 2 and 3 (each within the scatter of the next); then compound 4; then compound 1.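

Opening the ring on the ether oxygen is not a neutral change in this assay: butyl gives an 11-fold higher number from compound 3 to compound 4 (1.05 log units; beyond the scatter) and a 15-fold higher number from compound 2 to compound 4 (1.16 log units; beyond the scatter), so ring against chain matters far more here than the ring size change did. Butyl still keeps part of the gain over the aryl group, with a 4.8-fold lower number from compound 1 to compound 4 (0.68 log units; beyond the scatter), placing it between the cycloalkyl groups and 4-methylphenyl. Nothing available explains the cost of losing the ring.

Butyl has 4 carbon against 5 in cyclopentyl, so ring loss and chain length remain unseparated. From the compounds shown here alone, a longer chain such as pentyl or hexyl, or a smaller ring such as cyclobutyl, remains open.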